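A few compounds are considered here, and "the series" means these few. Any claim that something is new, unique, unknown or untested is made for them only; others in the source may bear on it.

Compound 2 `CCOC(=O)[C@]1(C(=O)Nc2ccccc2)C[C@H]1c1cc(OC)c(OC)c(OC)c1` was tested in a functional assay on K562 cells (Homo sapiens) for cytotoxicity, read by MTT assay, with a stated time of 48 h; a lower number here means a stronger inhibitor, a higher number a weaker inhibitor. In this assay compound 2 gives > 100000 nM, which is a limit of the assay rather than a measured number. Compound 1 `CCOC(=O)C1(C(=O)Nc2ccccc2)CC1c1cc(OC)c(OC)c(OC)c1` differs from compound 2 only in that one is drawn with a defined configuration and the other without (the fact that one of compounds 1 and 2 is drawn with a defined configuration and the other without, at the place where they differ). In this assay compound 1 gives > 100000 nM; > 100000 nM (2 entries), again a limit. Compound 3 `CCOC(=O)C1(C(=O)NCc2ccc(C)cc2)CC1c1cc(OC)c(OC)c(OC)c1` gives > 100000 nM; > 100000 nM (2 entries) in this assay, also a limit. Compound 4 `CCOC(=O)[C@]1(C(=O)NCc2ccc(C)cc2)C[C@H]1c1cc(OC)c(OC)c(OC)c1` is not yet measured; it differs from compound 2 by 4-methylbenzyl in place of phenyl on an amide-type nitrogen. Going by the values given here, no step between measured compounds is known, so the step is expected to be a step that the limit leaves unreadable from compound 2 to compound 4, none beyond the scatter. Compound 4 is expected to give about 200000 nM, between 100000 nM and 500000 nM, most likely reported as a limit.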

Compound 4, half-maximal inhibitory concentration: > 100000 nM
Compound 4: only a limit was reported (the forecaster's own chance of this, stated with the estimate: 90%); the middle value lies beyond the limit too.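

Going by these compounds alone, compound 2 and compound 4 both gave only a limit in this assay, so no step between them can be read. The compounds shown leave open whether 4-methylbenzyl in place of phenyl on an amide-type nitrogen changes the cytotoxicity at all.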